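Swapping the Sulfonyl Cap: Cytotoxicity Expectations

The source may hold more compounds than are shown below. What is called first, only, known or untested is meant among the compounds shown, and "the series" means these compounds.

Compound 1 `Cc1ccc(-c2c3c(nc(C)c2C(OC(C)(C)C)C(=O)O)CCN(S(C)(=O)=O)C3)cc1` was tested in an ADME assay on MT2 cells (Homo sapiens) for cytotoxicity, read by XTT assay, with a stated time of 4 days; on this read-out higher numbers stand for lower toxicity in this test and lower numbers for higher toxicity in this test. Compound 1 reaches only the limit of the test, > 40000 nM, so no number is known for it. Compound 2 `Cc1ccc(CCCN2CCc3nc(C)c([C@H](OC(C)(C)C)C(=O)O)c(-c4cc(F)c5c(c4C)CCCO5)c3C2)cc1F` likewise gives a limit, > 40000 nM. Compound 3 `Cc1ccc(-c2c3c(nc(C)c2[C@H](OC(C)(C)C)C(=O)O)CCN(Cc2ccccc2)C3)cc1` also gives a limit, > 40000 nM. Compound 1 thus stands where every value shown stands: at the limit of > 40000 nM in this assay, at which 3 of the 3 values shown sit. Compound 4 `COC(=O)N1CCc2nc(C)c(C(OC(C)(C)C)C(=O)O)c(-c3ccc(C)cc3)c2C1` differs from compound 1 in one place: methoxycarbonyl in place of methylsulfonyl on an amine nitrogen in a ring. Going by the values given here, all three measured compounds end at the same limit, so no step between them can be sized. For compound 4 no shift beyond the scatter is expected in this assay. Compound 4 is therefore expected to sit at 60000 nM, within 30000 nM to 200000 nM, an expected step that the limit leaves unreadable from compound 1 to compound 4 that means essentially no change.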

Compound 4, half-maximal cytotoxic concentration: > 40000 nM
Compound 4: no number, only a limit (the forecaster's own chance of this, stated with the estimate: 85%); the middle value does not contradict the limit.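

Going by these compounds alone, compound 1 and compound 4 both stop at the limit of this assay, so no step between them can be read. The compounds shown leave open whether swapping the group on the ring nitrogen changes cytotoxicity at all.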